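From Methoxy to Morpholin-4-yl on a Carbonyl Carbon

The source may report more compounds than this note shows. Statements on the series, on what has been measured and on what is new or still open speak of the compounds shown alone.

In a functional assay on MDA-MB-231 cells (Homo sapiens) for inhibition, read by sulforhodamine B assay, with a stated time of 72 h (a higher number here means a weaker inhibitor of growth, a lower number a stronger inhibitor of growth), compound 3 `COC(=O)/C=C/c1ccncc1-c1ccc2ccccc2c1` gives 4710 nM. Compound 1 `CNC(=O)/C=C/c1ccncc1-c1ccc2ccccc2c1` gives 8680 nM in this assay. That gap is a 1.8-fold lower number from compound 1 to compound 3 (0.27 log units; within the scatter), so the two stand together. Compound 2 `COC1CN(C(=O)/C=C/c2ccncc2-c2ccc3ccccc3c2)C1` reaches only a limit, > 10000 nM. The gap there is an at least 2.1-fold lower number from compound 2 to compound 3 (0.32 log units; beyond the scatter), which sets compound 3 apart from this limit.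

Compound 4 `O=C(/C=C/c1ccncc1-c1ccc2ccccc2c1)N1CCOCC1` has morpholin-4-yl in place of methoxy on a carbonyl carbon. Going by the values given here, two measured steps bear on this change, both read in reverse, since each puts methoxy in place of another group on the same carbonyl carbon. One is a 1.8-fold lower number from compound 1 to compound 3 (0.27 log units; within the scatter), and the other is an at least 2.1-fold lower number from compound 2 to compound 3 (0.32 log units; beyond the scatter). Neither replaces morpholin-4-yl itself, but together they suggest a modest rise in the number on leaving methoxy, though compound 4 may be reported only as a limit. The expected change is a 1.9-fold higher number from compound 3 to compound 4 (0.28 log units; within the scatter). Compound 4 is estimated at 9000 nM, with an expected range of 4500 nM to 18000 nM.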

Compound 4, concentration for 50% growth inhibition: 8980 nM
Compound 4: the middle estimate sits 1.0-fold (0.00 log units) above what was measured; measured number inside the range.
By their numbers in this assay, from the lowest: compounds 3, 1 and 4 (each within the scatter of the next). At a limit, above all of these: compound 2.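

In this assay, morpholin-4-yl in place of methoxy on the carbonyl carbon gives a 1.9-fold higher number from compound 3 to compound 4 (0.28 log units; within the scatter), so a six-membered ring at this place is not told apart from methoxy. Against methylamino the step is a 1.0-fold higher number from compound 1 to compound 4 (0.01 log units; within the scatter), so the three groups with exact numbers, methoxy, methylamino and morpholin-4-yl, stand together at this position. Against 3-methoxyazetidin-1-yl the step is an at least 1.1-fold lower number from compound 2 to compound 4 (0.04 log units; that floor lies within the scatter), which cannot be read as a real difference, since compound 2 gives only a limit: the limit of > 10000 nM in this assay, at which 1 of the 4 values shown sits.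

The compounds shown leave open whether any group on this carbonyl carbon moves the number beyond the scatter from these three, such as a piperazine, a free carboxylic acid or a longer chain on the amide nitrogen. They also leave open whether the same change would read alike on another core.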